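Sulfonyl in place of carbamoyl on the aryl ring

A few compounds are considered here, and "the series" means these few. Any claim that something is new, unique, unknown or untested is made for them only; others in the source may bear on it.

Working notes on a small set of sulfonamide-linked amides. Compound 1 `CCN(CC)S(=O)(=O)c1ccc(S(=O)(=O)N2CCC[C@@H](C(=O)N[C@@H]3CCN(C(=O)OC(C)(C)C)C3)C2)cc1` in a functional assay on BXPC-3 cells (Homo sapiens) for inhibition, read by MTT assay, with a stated time of 7 days (a lower number here means a stronger inhibitor, a higher number a weaker inhibitor), gives 400 nM. Compound 2 `CCN(CC)S(=O)(=O)c1ccc(S(=O)(=O)N2CCC[C@@H](C(=O)NC3CCN(C(=O)OC(C)(C)C)CC3)C2)cc1` in this assay gives 300 nM. Compound 3 `CCN(CC)C(=O)c1ccc(S(=O)(=O)N2CCC[C@@H](C(=O)N3CCN(c4nc(C(C)C)no4)CC3)C2)cc1` in this assay gives 1400 nM, the highest of the three numbers; its gap to compound 1 and to compound 2 lies beyond the scatter, while compound 1 and compound 2 lie within the scatter of each other, so no order between those two is claimed. For the measured compounds named here, compound 3 differs from the other two in more than one place, so no single step between measured compounds is available.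

Compound 4 `CCC(CC)S(=O)(=O)c1ccc(S(=O)(=O)N2CCC[C@@H](C(=O)N3CCN(c4nc(C(C)C)no4)CC3)C2)cc1` is the next point. It differs from compound 3 in one place: (pentan-3-yl)sulfonyl in place of diethylcarbamoyl on an aromatic carbon. Compounds 1 and 2 also carry a sulfonyl on that aromatic carbon, and both sit lower in this assay than compound 3, but their amide ends differ as well, so that comparison is only suggestive. The expected step from compound 3 to compound 4 is a modest move toward a lower number, a 1.8-fold lower number from compound 3 to compound 4 (0.24 log units; within the scatter), with a fair chance that it stays within the scatter. Compound 4 is therefore expected to give about 800 nM in this assay, with a range from 250 nM to 2500 nM.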

Compound 4, half-maximal inhibitory concentration: 120 nM
The estimate for compound 4 lay 6.7-fold (0.82 log units) above the measured number; measured number outside the range, below it.
By their numbers in this assay, from the lowest: compound 4; then compounds 2 and 1 (each within the scatter of the next); then compound 3.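

In this assay, (pentan-3-yl)sulfonyl in place of diethylcarbamoyl on the aromatic carbon gives a 12-fold lower number from compound 3 to compound 4 (1.07 log units; beyond the scatter) with the rest of the molecule unchanged, a large step beyond the scatter. For the compounds shown here, this is the first single-place reading, and it shows that this position, para to a large group, is not indifferent to the group it carries. The two groups hold the same number of carbon atoms and neither has a ring, so the step comes with an exchange of the carbamoyl for a sulfonyl and of a nitrogen-linked for a carbon-linked alkyl end, and nothing shown here accounts for it.

Open, as far as these compounds go, is whether the sulfonyl or the pentan-3-yl end carries the step: a diethylsulfamoyl group on this carbon with the amide end of compound 4 would separate the two, as would a methylsulfonyl or a longer alkyl chain on the sulfonyl. Also open, from the compounds shown here alone, is how a carboxylic acid or a primary amine would read at this position, and whether the step holds with the tert-butyl carbamate amide ends of compound 1 and compound 2.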